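The source may hold more compounds than are shown below. What is called first, only, known or untested is meant among the compounds shown, and "the series" means these compounds.

Three compounds have been measured in a functional assay on T47D cells (Homo sapiens) for inhibition; on this read-out higher numbers stand for weaker inhibition and lower numbers for stronger inhibition:

Compound 1, `Oc1cccc(-c2cc(-c3ccccc3C(F)(F)F)cc(-c3ccccc3O)n2)c1`, gives 5680 nM.
Compound 2, `Oc1cccc(-c2cc(-c3cccc(C(F)(F)F)c3)cc(-c3ccccc3O)n2)c1`, gives 6340 nM.
Compound 3, `Oc1ccc(-c2cc(-c3ccccc3C(F)(F)F)cc(-c3ccccc3O)n2)cc1`, gives 7180 nM.

All three share a core that carries three aromatic rings, and they differ only in where a hydroxyl or a trifluoromethyl group sits on one of those rings. Compound 2 differs from compound 1 by 3-(trifluoromethyl)phenyl in place of 2-(trifluoromethyl)phenyl on an aromatic carbon, and in this assay this gave a 1.1-fold higher number from compound 1 to compound 2 (0.05 log units; within the scatter). Compound 3 differs from compound 1 by 4-hydroxyphenyl in place of 3-hydroxyphenyl on an aromatic carbon, and this gave a 1.3-fold higher number from compound 1 to compound 3 (0.10 log units; within the scatter). For the measured compounds named here, no step is counted between compound 2 and compound 3; their values lie close to one another.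

Compound 4, `Oc1ccc(-c2cc(-c3cccc(C(F)(F)F)c3)cc(-c3ccccc3O)n2)cc1`, has not yet been measured. It differs from compound 3 by 3-(trifluoromethyl)phenyl in place of 2-(trifluoromethyl)phenyl on an aromatic carbon. Going by the values given here, this is the same kind of change as the one from compound 1 to compound 2, made on a core that differs as 4-hydroxyphenyl in place of 3-hydroxyphenyl on an aromatic carbon: in compound 1 the changed group stands meta to a 3-hydroxyphenyl group, in compound 3 meta to a 4-hydroxyphenyl group. Because the earlier change gave a 1.1-fold higher number from compound 1 to compound 2 (0.05 log units; within the scatter), a step of a 1.1-fold higher number from compound 3 to compound 4 (0.04 log units; within the scatter) is expected in this assay. On that basis compound 4 is estimated at 7800 nM, expected to fall between 4000 nM and 16000 nM.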

Compound 4, half-maximal inhibitory concentration: > 50000 nM
Compound 4: a limit, no number (the forecaster's own chance of this, stated with the estimate: 5%); middle value at least 6.4-fold (0.80 log units) away from the limit.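

In this assay compound 4 gives > 50000 nM, which is a limit of the assay and not a number. Swapping 2-(trifluoromethyl)phenyl for 3-(trifluoromethyl)phenyl made no real difference on the core of compound 1, but on the core of compound 3 the same swap gives an at least 6.9-fold higher number from compound 3 to compound 4 (0.84 log units; beyond the scatter), so this change does not carry from one core to the other: the same change on two cores in this assay, a 1.1-fold higher number (0.05 log units; within the scatter) from compound 1 to compound 2 and an at least 6.9-fold higher number (0.84 log units; beyond the scatter) from compound 3 to compound 4, at least 6.2-fold (0.79 log units) apart, beyond the scatter of two such steps

Seen from the other side, putting 4-hydroxyphenyl in place of 3-hydroxyphenyl gives an at least 7.8-fold higher number from compound 2 to compound 4 (0.89 log units; beyond the scatter), so the two changes do not simply add up in these four compounds, and inhibition is lost only when both are present, although this rests on a single set of four compounds, does not give the true size of the step and does not explain the loss: the same change on two cores in this assay, a 1.3-fold higher number (0.10 log units; within the scatter) from compound 1 to compound 3 and an at least 7.8-fold higher number (0.89 log units; beyond the scatter) from compound 2 to compound 4, at least 6.2-fold (0.79 log units) apart, beyond the scatter of two such steps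

The compounds shown leave open whether the same loss would appear with a chlorine atom or a methoxy group in place of the trifluoromethyl group on either core. They also leave open how an amine or a carboxylic acid in place of the hydroxyl group would behave, and how far the true value of compound 4 lies from its limit.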